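Working notes: tolerance limits and a 2-phenylethenyl change

The compounds below may be only part of what the source reports. "The series", "measured", "known", "first", "only" and "open" are said of these compounds alone.

Measured so far:
compound 1 `COc1ccc(-c2nc(/C=C/c3cc4ccccc4nc3OC)no2)cc1` > 220000 nM
compound 2 `COc1nc2ccccc2cc1/C=C/c1noc(-c2ccccc2C)n1` > 230000 nM
compound 3 `COc1nc2ccccc2cc1/C=C/c1noc(-c2cccc(C)c2)n1` > 230000 nM

In an ADME assay on HepG2 cells (Homo sapiens) for cytotoxicity, read by sulforhodamine B assay, with a stated time of 48 h (a lower number here means that less compound is tolerated, a higher number that more compound is tolerated), compound 1 gives > 220000 nM, which is a limit of the assay and not a number. Compound 2 gives > 230000 nM, again a limit. Compound 3 gives > 230000 nM, also a limit. Compound 3 therefore stands at the upper edge of what the assay reports, alongside the other two. The steps a step that the two limits leave unreadable from compound 1 to compound 3 and a step that the two limits leave unreadable from compound 2 to compound 3 cannot be sized because both ends sit at the limit of > 220000 nM in this assay, at which 1 of the 3 values shown sits, or (the limit of > 230000 nM in this assay, at which 2 of the 3 values shown sit).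

Compound 4 `COc1nc2ccccc2cc1/C=C/c1noc(/C=C/c2ccccc2)n1` is obtained from compound 3 by the change (2-phenylethenyl in place of 3-methylphenyl on an aromatic carbon). Among the measured compounds shown here, no measured step bears readably on this change, since every value in hand is a limit. The only expectation that the data support is that compound 4 will likewise be tolerated up to the reporting limit, so the step of a number no higher from compound 3 to compound 4 (the limit leaves the size open) is expected to be none beyond the scatter. Compound 4 is estimated at 230000 nM in this assay, with a range of 100000 nM to 400000 nM.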

Compound 4, half-maximal cytotoxic concentration: > 225000 nM
Compound 4 ended at the assay's limit (the forecaster's own chance of this, stated with the estimate: 80%); the middle value does not contradict the limit.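

In this assay compound 4 gives > 225000 nM, which is a limit and not a number. Among the compounds shown here, compound 1, compound 2 and compound 3 also stand at limits, so no step to compound 4 can be read. The compounds shown leave open whether 2-phenylethenyl and the aryl groups it replaces differ at all in tolerated concentration.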